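Ester Side-Chain Replacement and Tolerated Concentration in Liver Cells

The source may hold more compounds than are shown below. What is called first, only, known or untested is meant among the compounds shown, and "the series" means these compounds.

Compound 1 `O=c1c(CCO)c(-c2ccccc2Cl)c2cc(Cl)ccc2n1-c1ccccc1` gives 26000 nM in an ADME assay on HepG2 2.2.15 cells (Homo sapiens) for cytotoxicity; a higher number here means that more compound is tolerated, a lower number that less compound is tolerated.
Compound 2 `COCC(=O)OCCc1c(-c2ccccc2Cl)c2cc(Cl)ccc2[nH]c1=O` gives 74000 nM in this assay.

Within the data shown here, of the two numbers measured so far, compound 2 stands highest in this assay; compound 1 gives the lower number, and the gap between them lies beyond the usual scatter of repeated measurements. Among the measured compounds shown here, no two measured compounds differ in only one place, so no single structural step can be read from the data.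

Compound 3 `O=C(CN1C(=O)c2ccccc2C1=O)OCCc1c(-c2ccccc2Cl)c2cc(Cl)ccc2[nH]c1=O` differs from compound 2 by a group of 11 heavy atoms (8 carbon, 1 nitrogen, 2 oxygen; one five-membered non-aromatic ring with 1 hetero atom, one six-membered aromatic ring of carbon only) in place of a group of 2 heavy atoms (1 carbon, 1 oxygen; no ring), on a saturated chain carbon bound to a carbonyl carbon. Nothing measured here shows how such a change affects the tolerated concentration. The expectation is a modest move downward in this assay, of a size close to the scatter. Compound 3 is estimated to give 50000 nM, with a range from 15000 nM to 150000 nM. This estimate corresponds to an expected 1.5-fold lower number from compound 2 to compound 3 (0.17 log units; within the scatter).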

Compound 3, half-maximal cytotoxic concentration: 960000 nM
Beside the measured number, compound 3's estimate is 19-fold (1.28 log units) below it; measured number outside the range, above it.
By their numbers in this assay, from the lowest: compound 1; then compound 2; then compound 3.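

On the saturated chain carbon bound to a carbonyl carbon, the ester side chain accepts a far larger group than methoxy: in this assay the replacement gives a 13-fold higher number from compound 2 to compound 3 (1.11 log units; beyond the scatter) and this step is large. The entering group carries a five-membered non-aromatic ring with 1 hetero atom and a six-membered aromatic ring of carbon only, and the tolerated concentration rises with this change rather than falls. This is the only step among the compounds shown that differs in one place, so it gives the sole direct reading of this position. Nothing measured here gives a reason for the rise. A single step cannot separate the contribution of the two rings from that of the added atoms. As far as these compounds go, how an amine, a carboxylic acid or a longer open chain would stand at this place remains open.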